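This account rests on a few compounds, and the source may have more. Where it says the series, first, only, none or still open, it means among the compounds named here.

Compound 1 `O=C1CSC(c2cccc(F)c2)N1CCN1CCCCC1` and compound 2 `O=C1CSC(c2ccc(Cl)cc2)N1CCN1CCCCC1` share one core and differ only in the substituted phenyl ring. In an ADME assay on Vero cells (Chlorocebus sabaeus) for cytotoxicity, read by neutral red uptake, tested at 25 ug/mL (a lower number here means a stronger effect, a higher number a weaker effect of the compound at the concentration tested), compound 1 gives 100%, while compound 2 gives 84%. Compound 2 therefore stands at the lower of the two numbers, with compound 1 above it by the step of a number 16 percentage points lower from compound 1 to compound 2 (beyond the scatter). Compound 3 `COc1ccc(C2SCC(=O)N2CCN2CCCCC2)cc1` has not yet been tested in this assay; it differs from compound 2 as follows: methoxy in place of chloro on an aromatic carbon. Among the compounds with values here, the single measured step, a number 16 percentage points lower from compound 1 to compound 2 (beyond the scatter), exchanges one substituted phenyl ring for another and was modest in size, so it bears on this change only loosely and sets no clear direction for a methoxy in place of chloro. Compound 3 is therefore expected to give about 90%, within a range from 74% to 100%. The expected step of a number 6 percentage points higher from compound 2 to compound 3 (within the scatter) is estimated to stay within the usual scatter.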

Compound 3, a percentage reported as activity, at one concentration (the size of the read-out at that concentration, not a potency): 100%
Compound 3: the middle estimate sits 10 percentage points below what was measured; the measured number falls inside the stated range.
By their numbers in this assay, from the lowest: compound 2; then compounds 1 and 3 (each within the scatter of the next).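

In this assay, methoxy in place of chloro on an aromatic carbon para to a large group gives a number 16 percentage points higher from compound 2 to compound 3 (beyond the scatter), so exchanging this one group, with its place on the ring unchanged, is enough to shift the read-out towards a weaker effect. The earlier step exchanged one substituted phenyl ring for another and so changed both the group and its place, whereas this one isolates the group, and of the pair at this position chloro carries the stronger effect. Nothing available accounts for the size or direction of this step.

On these data alone, whether the stronger effect is particular to chloro or would also appear with bromo, an amine or a carboxylic acid at this position remains open. So does whether chloro would give the same number on another carbon of the ring.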